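The source may report more compounds than this note shows. Statements on the series, on what has been measured and on what is new or still open speak of the compounds shown alone.

Compound 1 `O=C(Nc1nnc(-c2cccc(O)c2O)s1)c1ccccc1` gives 20700 nM in a functional assay on HL-60 cells (Homo sapiens) for cytotoxicity, read by MTT assay, with a stated time of 72 h; on this read-out lower numbers stand for stronger inhibition and higher numbers for weaker inhibition.
Compound 2 `CC(=O)Nc1nnc(-c2cccc(O)c2O)s1` gives 49000 nM in this assay.
Compound 3 `CC(=O)Nc1nnc(-c2ccc(O)c(O)c2)s1` gives 42500 nM in this assay.

The one change made in two pairs of these compounds is phenyl in place of methyl on a carbonyl carbon, and between the measured pair it produced a 2.4-fold lower number from compound 2 to compound 1 (0.37 log units; beyond the scatter). Compound 2 and compound 3 share the same atoms joined differently; the difference between the two cores is not broken down here, and their values lie close together. Compound 4 `O=C(Nc1nnc(-c2ccc(O)c(O)c2)s1)c1ccccc1` carries the same change on the core of compound 3: phenyl in place of methyl on a carbonyl carbon, at a place described in the same words as before. Because a 2.4-fold lower number from compound 2 to compound 1 (0.37 log units; beyond the scatter) was modest but beyond the scatter, a step of similar size is expected from compound 3 to compound 4, namely a 2.4-fold lower number from compound 3 to compound 4 (0.37 log units; beyond the scatter). Compound 4 is therefore estimated at 18000 nM, within a range from 8000 nM to 40000 nM.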

Compound 4, half-maximal inhibitory concentration: 17600 nM
Compound 4: the middle estimate sits 1.0-fold (0.01 log units) above what was measured, and the stated range covers the measured number.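

In this assay, phenyl in place of methyl on a carbonyl carbon gave a 2.4-fold lower number from compound 3 to compound 4 (0.38 log units; beyond the scatter) on this second core. Only two pairs are shown, so nothing follows for any further core, for any other read-out, or for why the number falls. Within these two pairs, however, the change carried from one core to the other with its size intact: the same change on two cores in this assay, a 2.4-fold lower number (0.37 log units; beyond the scatter) from compound 2 to compound 1 and a 2.4-fold lower number (0.38 log units; beyond the scatter) from compound 3 to compound 4, 1.0-fold (0.01 log units) apart, within the scatter of two such steps

Going by these compounds, whether a similar step would follow from other groups on the carbonyl carbon, such as ethyl, a longer chain or an amine, stays open. Also open, on these data alone, is how the values would respond if a methoxy group or a carboxylic acid stood in place of the hydroxyl groups.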